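Swapping a Chain Branch for a Methoxy Group

The compounds below may be only part of what the source reports. "The series", "measured", "known", "first", "only" and "open" are said of these compounds alone.

Among the measured compounds shown here, compound 2 `CSc1nc(NCC(C)C)c2cccnc2n1` gives 540 nM in a functional assay (Nicotiana tabacum) (on this read-out lower numbers stand for stronger inhibition and higher numbers for weaker inhibition), the lowest of the two numbers measured so far; its nearest neighbour, compound 1 `CSc1nc(NC2CC2)c2cccnc2n1`, gives 4900 nM. For the measured compounds named here, the only measured step, a 9.1-fold lower number from compound 1 to compound 2 (0.96 log units; beyond the scatter), concerns the group on a nitrogen on an aromatic ring. Compound 3 `COCCNc1nc(SC)nc2ncccc12` has not been measured yet. It differs from compound 2 by methoxymethyl in place of isopropyl on a saturated chain carbon bound to a nitrogen on an aromatic ring. The measured step exchanged a ring for a chain at that nitrogen, whereas the new change keeps a chain and puts an oxygen into it, so the earlier step offers little direct guidance. The expectation for compound 3 is therefore only a small step, a 2.0-fold higher number from compound 2 to compound 3 (0.31 log units; beyond the scatter), not clearly beyond the scatter. Compound 3 is estimated at 1100 nM, with a range from 300 nM to 4500 nM.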

Compound 3, half-maximal inhibitory concentration: 2530 nM
The estimate for compound 3 lay 2.3-fold (0.36 log units) below the measured number, within the range that was stated.
By their numbers in this assay, from the lowest: compound 2; then compounds 3 and 1 (each within the scatter of the next).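

In this assay, replacing isopropyl with methoxymethyl on a saturated chain carbon bound to a nitrogen on an aromatic ring gives a 4.7-fold higher number from compound 2 to compound 3 (0.67 log units; beyond the scatter) for a change that keeps the count of 3 heavy atoms. This position therefore responds to an exchange of one carbon for one oxygen, not only to the swap of a ring for a chain seen earlier. The 2-methoxyethyl group also gives up the advantage that isobutyl held over cyclopropyl, with a 1.9-fold lower number from compound 1 to compound 3 (0.29 log units; within the scatter) placing compound 3 and compound 1 within the scatter of each other. Nothing available here accounts for the effect of the oxygen. Still open, on these data alone, is how a hydroxyl group, an amine or a longer ether chain at this position would read in this assay.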